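A few compounds are considered here, and "the series" means these few. Any claim that something is new, unique, unknown or untested is made for them only; others in the source may bear on it.

Going by the values given here, compound 1 `CNc1nc(N)nc2c1ncn2/C=C1/CC1(CO)CO` is the only member of the pair with a numerical read-out in an ADME assay on HFF cells (Homo sapiens) for cytotoxicity, with a stated time of 8 days (on this read-out lower numbers stand for higher toxicity in this test and higher numbers for lower toxicity in this test), where compound 1 gives 265000 nM. Compound 2 `CCCCCCCCOc1nc(N)nc2c1ncn2/C=C1/CC1(CO)CO` carries octyloxy in place of methylamino on an aromatic carbon. In this assay compound 2 returns > 300000 nM, which is a limit rather than a number. The step of an at least 1.1-fold higher number from compound 1 to compound 2 (0.05 log units; that floor lies within the scatter) is accordingly known only as a floor. Compound 2 thus stands at the upper edge of what this assay reports, namely (the limit of > 300000 nM in this assay, at which 1 of the 2 values shown sits). Compound 3 `CC(C)CNc1nc(N)nc2c1ncn2/C=C1/CC1(CO)CO` differs from compound 2 as follows: isobutylamino in place of octyloxy on an aromatic carbon. Among the compounds with values here, the only measured step that bears on this new pair is the one from compound 1 to compound 2, whose floor sits within the scatter, so no step beyond the scatter is expected in this assay from compound 2 to compound 3 in either direction; the entering isobutylamino restores a hydrogen-bond donor and so brings the substituent nearer to the methylamino of compound 1. The estimate for compound 3 is 240000 nM, with a range from 120000 nM to 300000 nM. The step this estimate implies is an at least 1.2-fold lower number from compound 2 to compound 3 (0.09 log units; that floor lies within the scatter), expected to remain within the scatter.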

Compound 3, half-maximal cytotoxic concentration: > 300000 nM
Compound 3: a limit, no number; the forecaster's own chance of this, stated with the estimate: 35%; middle value at least 1.2-fold (0.09 log units) from the limit.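

In this assay compound 3 gives a limit and not a number, so an amine-linked group on this aromatic carbon, and not only octyloxy, can reach the upper edge of the reported range: the limit of > 300000 nM in this assay, at which 2 of the 3 values shown sit.

Set against the smaller amine, the record is an at least 1.1-fold higher number from compound 1 to compound 3 (0.05 log units; that floor lies within the scatter), so the isobutylamino group at this position gives no sign of a lower number than methylamino, although a floor of this size cannot separate the two. The step between the octyloxy and isobutylamino compounds cannot be read, since both values are limits, and the series therefore gives no ranking of the oxygen-linked and nitrogen-linked groups at this position.

From the compounds shown here alone, how far compound 2 and compound 3 lie past the limit remains open, as does any real size of the change from methylamino to isobutylamino. Also open, going by these compounds, is whether a longer chain on the amine, a cyclopropylamino group or a piperidine at this aromatic carbon would stay at the limit or return a measurable number in this assay.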